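The compounds below may be only part of what the source reports. "The series", "measured", "known", "first", "only" and "open" are said of these compounds alone.

Measured in a functional assay on 4T1 cells (Mus musculus) for cytotoxicity, read by MTT assay, with a stated time of 48 h; on this read-out higher numbers stand for weaker inhibition and lower numbers for stronger inhibition:
- Compound 1 `COc1ccc(/C=C/C(=O)/C=C/c2cc3ccccc3nc2Cl)cc1`: > 10000 nM, a limit
- Compound 2 `COc1ccc(/C=C/C(=O)/C=C/c2cc3ccccc3nc2Oc2ccccc2)cc1OC`: > 10000 nM, a limit
- Compound 3 `COc1cc(OC)c(OC)cc1/C=C/C(=O)/C=C/c1cc2ccccc2nc1Oc1ccccc1`: 7630 nM

For the measured compounds named here, compound 3 holds the only actual number in this small set, since the other two values are limits. Compound 4 `COc1cc(OC)c(OC)cc1/C=C/C(=O)/C=C/c1cc2ccccc2nc1Oc1cccc(Cl)c1` differs from it by chloro in place of hydrogen on an aromatic carbon, turning phenoxy into 3-chlorophenoxy. Going by the values given here, the only measured step, an at least 1.3-fold lower number from compound 2 to compound 3 (0.11 log units; that floor lies within the scatter), concerns methoxy rather than chloro, so it offers weak guidance and no firm direction. Accordingly, no change beyond the scatter is expected in this assay. The estimated 1.4-fold lower number from compound 3 to compound 4 (0.14 log units; within the scatter) stays within that scatter. For compound 4 the expected value is 5500 nM, with an estimated range of 2000 nM to 12000 nM.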

Compound 4, half-maximal inhibitory concentration: > 10000 nM
Compound 4 gave a limit, no number; the forecaster's own chance of this, stated with the estimate: 20%; middle value at least 1.8-fold (0.25 log units) away from the limit.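

In this assay, this is the first change shown on the phenoxy group itself, and it reads as an at least 1.3-fold higher number from compound 3 to compound 4 (0.11 log units; that floor lies within the scatter), so chloro at this place brought no gain. Compound 4 gives > 10000 nM, which is a limit. The true size of the step stays open because the read-out stops at the same limit for most of the set: the limit of > 10000 nM in this assay, at which 3 of the 4 values shown sit.

The compounds shown leave open whether an amine or a carboxylic acid at this place on the phenoxy group would give a measurable number. They also leave open how fluoro would compare with chloro here.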